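Ring to chain on the quinazoline-type core, with scrutiny

A few compounds are considered here, and "the series" means these few. Any claim that something is new, unique, unknown or untested is made for them only; others in the source may bear on it.

Compound 3 `COCC(=O)NC1CCN(c2nc(C)c3cc(NC(=O)/C=C/c4ccc(OC(F)(F)F)cc4)ccc3n2)CC1` stands highest of the three compounds in an ADME assay on microsomes from liver (Mus musculus) for metabolic stability, with a stated time of 30 min (on this read-out lower numbers stand for a less stable compound and higher numbers for a more stable compound), where compound 3 gives 57%. Its nearest neighbour is compound 2 `Cc1nc(NCCNC(=O)C2CC2)nc2ccc(NC(=O)/C=C/c3ccc(OC(F)(F)F)cc3)cc12`, which in this assay gives 38%, and the lowest number belongs to compound 1 `Cc1nc(N(C)C2CCCC2)nc2ccc(NC(=O)/C=C/c3ccc(Cl)cc3)cc12`, which in this assay gives 12%. Within the data shown here, only one single-point step is documented: a number 19 percentage points higher from compound 2 to compound 3 (beyond the scatter), a modest gain that went beyond the scatter.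

Compound 4 `Cc1nc(NCCCNS(C)(=O)=O)nc2ccc(NC(=O)/C=C/c3ccc(OC(F)(F)F)cc3)cc12` differs from compound 3 in one place: (3-(methanesulfonamido)propyl)amino in place of 4-(((methoxymethyl)carbonyl)amino)piperidin-1-yl on an aromatic carbon. This step runs against the documented one, since the group that leaves carries a six-membered non-aromatic ring and the group that enters has no ring, much as the move from compound 2 to compound 3 had introduced such a ring. On that basis the account expects compound 4 to fall back from compound 3, with an estimated step of a number 17 percentage points lower from compound 3 to compound 4 (beyond the scatter) in this assay, beyond the scatter but not large. Compound 4 is therefore estimated at about 40%, with a range from 25% to 58%.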

Compound 4, percent of the compound remaining: 58%
For compound 4 the middle estimate is 18 percentage points below the measured one; the measured number falls inside the stated range.
By their numbers in this assay, from the lowest: compound 1; then compound 2; then compounds 3 and 4 (each within the scatter of the next).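

In this assay the record gives a number 1 percentage points higher from compound 3 to compound 4 (within the scatter), so at this position the open chain (3-(methanesulfonamido)propyl)amino, with no ring, stands level with the six-membered non-aromatic ring of 4-(((methoxymethyl)carbonyl)amino)piperidin-1-yl. A ring in this group is therefore not required for this level of stability, and the ring-free compound 2 goes against any link between a ring and stability, as the change within the chain alone gives a number 20 percentage points higher from compound 2 to compound 4 (beyond the scatter). No measured finding on these compounds explains either step.

On these data alone, in that change from compound 2 the end group and the chain length differ together, so the share of each stays open. How a (2-(methanesulfonamido)ethyl)amino chain, or a piperidine carrying a methanesulfonamido group, would stand in this assay is also unknown from the compounds shown.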